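The source may report more compounds than this note shows. Statements on the series, on what has been measured and on what is new or still open speak of the compounds shown alone.

In a functional assay on DU-145 cells (Homo sapiens) for inhibition (on this read-out higher numbers stand for weaker inhibition of growth and lower numbers for stronger inhibition of growth), compound 1 `O=S(=O)(/C=C/c1ccc(F)cc1)Cc1ccc(Nc2ncnc3ccccc23)cc1` gives 300 nM. Compound 2 `N#Cc1ccc(/C=C/S(=O)(=O)Cc2ccc(Nc3ncnc4ccccc34)cc2)cc1` gives > 100000 nM, which is a limit and not a number. Compound 3 `O=S(=O)(/C=C/c1ccc(Cl)cc1)Cc1ccc(Nc2ncnc3ccccc23)cc1` also stands only at a limit, > 100000 nM. Compound 4 `O=S(=O)(/C=C/c1ccc(O)cc1)Cc1ccc(Nc2ncnc3ccccc23)cc1` differs from it by one change, hydroxy in place of chloro on an aromatic carbon. Two measured steps at this place bear on it, an at least 330-fold higher number from compound 1 to compound 2 (2.52 log units; beyond the scatter) and an at least 330-fold higher number from compound 1 to compound 3 (2.52 log units; beyond the scatter), both large, while a step that the two limits leave unreadable from compound 2 to compound 3 cannot be read. None of them involves hydroxy. Within the data shown here, compound 1 at 300 nM is the only true number. A moderate move to a lower number is expected, though another limit is quite possible. The expected step is an at least 6.6-fold lower number from compound 3 to compound 4 (0.82 log units; beyond the scatter). For compound 4 the estimated value is 15000 nM, within a range of 300 nM to 100000 nM.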

Compound 4, concentration for 50% growth inhibition: 19000 nM
Compound 4: middle estimate off by 1.3-fold (0.10 log units), on the low side, and the stated range covers the measured number.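

At the position para to a large group, hydroxy brings the compound back from the limit, with an at least 5.2-fold lower number from compound 3 to compound 4 (0.72 log units; beyond the scatter) and an at least 5.2-fold lower number from compound 2 to compound 4 (0.72 log units; beyond the scatter), so a true number here is not confined to fluoro. Fluoro nevertheless stays clearly ahead of hydroxy, with a 63-fold higher number from compound 1 to compound 4 (1.80 log units; beyond the scatter). Both lower-number steps are open-ended because each starts from a limit: the limit of > 100000 nM in this assay, at which 2 of the 4 values shown sit.

From the compounds shown here alone, the step between compound 2 and compound 3 cannot be read, so how these two compare stays unknown. Going by these compounds, whether an amine or a methoxy group at this position would give a true number also remains open.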